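Fluoro to nitro on the styryl arm of compound 2

The source may report more compounds than this note shows. Statements on the series, on what has been measured and on what is new or still open speak of the compounds shown alone.

Compound 1, `O=c1cc(/C=C/c2ccc(OC(F)(F)F)cc2)oc2ccccc12`, gives 28900 nM in a functional assay on PC-3 cells (Homo sapiens) for antiproliferative activity, read by MTT assay, with a stated time of 12 h; a higher number here means a weaker inhibitor, a lower number a stronger inhibitor.
Compound 2, `COc1cc(OC)c2c(=O)cc(/C=C/c3ccc(F)cc3)oc2c1`, gives > 40000 nM in this assay; this is a limit of the assay, not a number.
Compound 3, `COc1cc(OC)c2c(=O)cc(/C=C/c3ccncc3)oc2c1`, gives > 40000 nM in this assay; this too is a limit of the assay.

Compound 2 is therefore not placed by a number: it stands at the limit, as the limit of > 40000 nM in this assay, at which 2 of the 3 values shown sit, shows, and only compound 1 of the three carries a measured value. The unmeasured compound 4, `COc1cc(OC)c2c(=O)cc(/C=C/c3ccc([N+](=O)[O-])cc3)oc2c1`, differs from compound 2 in one place: nitro in place of fluoro on an aromatic carbon.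

Among the measured compounds shown here, the only step among the measured compounds, a step that the two limits leave unreadable from compound 2 to compound 3, is unreadable, because both ends sit at the limit. It changes the ring rather than a substituent on it, so it does not reach the present change. No measured step bears on exchanging fluoro for nitro, and no direction can be read from the numbers shown.

Compound 4 is therefore expected to remain weak, near the limit, and its estimated value is 38000 nM, between 15000 nM and 90000 nM. The step this estimate implies, an at least 1.0-fold lower number from compound 2 to compound 4 (0.02 log units; that floor lies within the scatter), is expected to be no more than the scatter permits, with a real chance that only a limit is reported again.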

Compound 4, half-maximal inhibitory concentration: > 40000 nM
Compound 4 gave a limit, no number; the forecaster's own chance of this, stated with the estimate: 60%; middle value at least 1.0-fold (0.02 log units) from the limit.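

Compound 4, like compound 2, stands at a limit and not at a number, so no step can be read between the two: the limit of > 40000 nM in this assay, at which 3 of the 4 values shown sit. The compounds shown leave open whether nitro and fluoro at this place differ in activity at all.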